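A Second Methoxy on the Hydroxyphenyl Arm

The compounds below may be only part of what the source reports. "The series", "measured", "known", "first", "only" and "open" are said of these compounds alone.

Compound 2 `COc1ccc(/C=C/C(=O)C(=Cc2ccc(O)c(OC)c2)C(=O)/C=C/c2ccc(OC)cc2OC)c(OC)c1` was tested in a functional assay on A549 cells (Homo sapiens) for antiproliferative activity, read by sulforhodamine B assay, with a stated time of 48 h (on this read-out higher numbers stand for weaker inhibition and lower numbers for stronger inhibition), where compound 2 gives 590 nM. That is the higher of the two numbers available. The other compound, compound 1 `COc1cc(C=C(C(=O)/C=C/c2cccc(OC)c2OC)C(=O)/C=C/c2cccc(OC)c2OC)ccc1O`, gives 130 nM in this assay, so compound 2 is the weaker of the two by a margin beyond the usual scatter. Compound 3 `COc1ccc(/C=C/C(=O)C(=Cc2cc(OC)c(O)c(OC)c2)C(=O)/C=C/c2ccc(OC)cc2OC)c(OC)c1` has not yet been measured. It differs from compound 2 in one place: methoxy in place of hydrogen on an aromatic carbon. Put another way, the 4-hydroxy-3-methoxyphenyl unit of compound 2 becomes a 4-hydroxy-3,5-dimethoxyphenyl unit in compound 3, with the new methoxy sitting ortho to the hydroxy group and meta to the existing methoxy group. Among the measured compounds shown here, no measured pair in this set shows what such an added methoxy does, so both the size and the direction of the step are open. The expectation here is a step of a 1.2-fold lower number from compound 2 to compound 3 (0.07 log units; within the scatter), modest and lying within or close to the scatter. Compound 3 is therefore estimated at 500 nM, within a range from 150 nM to 1800 nM.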

Compound 3, half-maximal inhibitory concentration: 300 nM
Compound 3: middle estimate off by 1.7-fold (0.22 log units), on the high side, within the range that was stated.
By their numbers in this assay, from the lowest: compound 1; then compounds 3 and 2 (each within the scatter of the next).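

In this assay, a methoxy in place of hydrogen on this aromatic carbon, ortho to the hydroxy group and meta to the existing methoxy group, gives a 2.0-fold lower number from compound 2 to compound 3 (0.29 log units; within the scatter) and so leaves the two numbers indistinguishable on this read-out. Among the compounds shown here, this is the first comparison in the set in which only one place differs, and it shows that the 4-hydroxy-3-methoxyphenyl unit can become a 4-hydroxy-3,5-dimethoxyphenyl unit without a shift beyond the usual scatter. No measurement shown here offers an explanation for this outcome.

Methoxy is the only group shown at this position, so what an amine, a carboxylic acid or a longer chain such as ethoxy would do on the same carbon remains open. Compound 1 differs from the other two in more than one place, so the compounds shown also cannot assign its number to any single structural change, nor do they show whether the hydroxy group itself matters.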